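A few compounds are considered here, and "the series" means these few. Any claim that something is new, unique, unknown or untested is made for them only; others in the source may bear on it.

Three measured compounds frame the question. Compound 1 `O=C(/C=C/c1ccncc1-c1ccc2[nH]ccc2c1)N1CCOCC1` gives 190 nM in an assay on a protein complex for inhibition of CDK8/Cyclin C (Homo sapiens), with a stated time of 1 h; on this read-out lower numbers stand for stronger inhibition and higher numbers for weaker inhibition. Compound 2 `COC(=O)/C=C/c1ccncc1-c1ccc2ccccc2c1` gives 40.6 nM in this assay, while compound 3 `Cn1ccc2cc(-c3cnccc3/C=C/C(=O)N3CCOCC3)ccc21` gives 247 nM. Compound 3 thus stands highest of the three numbers: compound 1 is its nearest neighbour, and compound 2 lies furthest from it, beyond the scatter. Going by the values given here, the only step between measured compounds that differ in one place is a 1.3-fold higher number from compound 1 to compound 3 (0.11 log units; within the scatter), where a methyl replaces a hydrogen on an aromatic nitrogen.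

Compound 4 `CNC(=O)/C=C/c1ccncc1-c1ccc2c(ccn2C)c1` differs from compound 3 in one place: methylamino in place of morpholin-4-yl on a carbonyl carbon. Among the compounds with values here, no measured step changes the group on the carbonyl carbon, so none bears directly on this change; compound 2 carries a different group there, but it also differs from compound 3 in its aromatic part, so its lower number cannot be assigned to either change. Within the data shown here, with no directly comparable step, the expectation for compound 4 is a 1.1-fold lower number from compound 3 to compound 4 (0.05 log units; within the scatter), in effect no movement beyond the scatter. The estimate for compound 4 is therefore 220 nM, with a range from 70 nM to 700 nM.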

Compound 4, half-maximal inhibitory concentration: 77.6 nM
Compound 4: the middle estimate sits 2.8-fold (0.45 log units) above what was measured; the range from low to high includes it.
By their numbers in this assay, from the lowest: compounds 2 and 4 (each within the scatter of the next); then compounds 1 and 3 (each within the scatter of the next).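

In this assay the group on the carbonyl carbon proves able to move the number: methylamino in place of morpholin-4-yl gives a 3.2-fold lower number from compound 3 to compound 4 (0.50 log units; beyond the scatter) and so lies beyond the scatter, which the earlier step on the aromatic nitrogen did not. The six-membered non-aromatic ring of morpholin-4-yl is therefore not required on the core of compound 3 for a number of this size. The step changes the ring, the size and the hydrogen-bond donor count at once, and no measurement available explains the shift.

Going by these compounds, whether the amide hydrogen or the small size of methylamino matters remains open, and dimethylamino, ethylamino or an unsubstituted amino group on the same carbonyl carbon would separate the two. Also open, on these data alone, is whether the step carries over to the core of compound 1, with hydrogen on the aromatic nitrogen.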